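Halogen on the aryl ether: from compound 3 to compound 4

The source may report more compounds than this note shows. Statements on the series, on what has been measured and on what is new or still open speak of the compounds shown alone.

In a functional assay on HL-60 cells (Homo sapiens) for antiproliferative activity, read by MTT assay, with a stated time of 72 h (on this read-out lower numbers stand for stronger inhibition and higher numbers for weaker inhibition), compound 3 `NC1=NC2(CCOCC2)N(OCCCOc2ccc(Cl)cc2)C(N)=N1` gives 330 nM, the lowest of the three numbers. Compound 1 `NC1=NC2(CCOCC2)N(OCCCOc2cc(Cl)c(Cl)cc2Cl)C(N)=N1` gives 2360 nM and compound 2 `Cc1ccc(OCCCON2C(N)=NC(N)=NC23CCOCC3)cc1` gives 2580 nM; the steps of a 7.2-fold lower number from compound 1 to compound 3 (0.85 log units; beyond the scatter) and a 7.8-fold lower number from compound 2 to compound 3 (0.89 log units; beyond the scatter) show that a 4-chlorophenyl group sits well here, while a 1.1-fold higher number from compound 1 to compound 2 (0.04 log units; within the scatter) separates the other two by nothing. Compound 4 `NC1=NC2(CCOCC2)N(OCCCOc2cccc(Br)c2)C(N)=N1` carries 3-bromophenyl in place of 4-chlorophenyl on an oxygen on a saturated carbon. Among the compounds with values here, a halogen stays on the ring but its position moves, and no measured pair covers that move; compound 1 shows that extra halogens elsewhere on the ring cost potency. A modest rise in the number is therefore expected, a 2.3-fold higher number from compound 3 to compound 4 (0.36 log units; beyond the scatter), so compound 4 is estimated at 750 nM in this assay, between 250 nM and 2500 nM.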

Compound 4, half-maximal inhibitory concentration: 560 nM
Estimate against measurement, compound 4: 1.3-fold (0.13 log units) above; the range from low to high includes it.
By their numbers in this assay, from the lowest: compounds 3 and 4 (each within the scatter of the next); then compounds 1 and 2 (each within the scatter of the next).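

The step from 4-chlorophenyl to 3-bromophenyl stays within the scatter (a 1.7-fold higher number from compound 3 to compound 4 (0.23 log units; within the scatter)), so a single halogen on the ring need not be a chlorine held in the 4-position. The 3-bromophenyl group also stands clear of the other two aryl groups (a 4.6-fold lower number from compound 2 to compound 4 (0.66 log units; beyond the scatter); a 4.2-fold lower number from compound 1 to compound 4 (0.62 log units; beyond the scatter)), so the low numbers no longer rest on 4-chlorophenyl alone. No measurement shown accounts for these differences.

Halogen identity and ring position change together here, so their separate contributions remain unresolved. From the compounds shown here alone, how an amine or a carboxylic acid on the ring, or a longer chain before the oxygen, would read also stays open.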